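Shortening the Ester Chain of a Catechol Ester

The source may report more compounds than this note shows. Statements on the series, on what has been measured and on what is new or still open speak of the compounds shown alone.

Compound 2 `CCCCCCCCCCCC(=O)OCCc1ccc(O)c(O)c1` is a catechol joined through a short linker to an ester bearing a long saturated chain. Among the compounds with values here, in a toxicity assay on MRC5 cells (Homo sapiens) for inhibition, read by MTT assay, with a stated time of 72 h (on this read-out higher numbers stand for weaker inhibition and lower numbers for stronger inhibition), compound 2 gives 38100 nM, the only plain number among the two values shown. Compound 1 `CCCCCCCCCCC(=O)OCCc1ccc(O)c(O)c1` carries a chain one carbon shorter. In this assay compound 1 reaches only the limit > 50000 nM (the limit of > 50000 nM in this assay, at which 1 of the 2 values shown sits). The step of an at least 1.3-fold lower number from compound 1 to compound 2 (0.11 log units; that floor lies within the scatter) thus has a floor that lies within the scatter.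

Compound 3 `CCCCCCCC(=O)OCCc1ccc(O)c(O)c1` shortens the chain further: hydrogen in place of butyl on a saturated chain carbon, seven bonds along the chain from a carbonyl carbon. Within the data shown here, only that single step bears on this change, and it moved from a limit to a number as the chain grew; cutting the chain by a larger amount points, if anything, the other way, toward weaker inhibition and a value back at the limit. Compound 3 is therefore expected near 65000 nM, with a range from 30000 nM to 150000 nM. The expected step is a 1.7-fold higher number from compound 2 to compound 3 (0.23 log units; within the scatter).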

Compound 3, half-maximal inhibitory concentration: 104000 nM
Compound 3: the middle estimate sits 1.6-fold (0.20 log units) below what was measured, within the range that was stated.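

Until now the chain length had only a step whose floor lay within the scatter. In this assay, within the data shown here, the change from butyl to hydrogen, on a saturated chain carbon seven bonds along the chain from a carbonyl carbon, gives the first step that can be read in full: a 2.7-fold higher number from compound 2 to compound 3 (0.44 log units; beyond the scatter). Between these two compounds, the shorter chain therefore goes with weaker inhibition of the cells. The step between compound 1 and compound 3 cannot be read, because the value of compound 1 is a limit: the limit of > 50000 nM in this assay, at which 1 of the 3 values shown sits.

Two compounds with plain numbers cannot show how the read-out changes with each added carbon, or whether a longer chain than that of compound 2 would lower the number further. From the compounds shown here alone, how an amide in place of the ester, or an amine at the end of the chain, would behave also remains open.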